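Amide-linked thiadiazole series: integument inhibition notes

This account rests on a few compounds, and the source may have more. Where it says the series, first, only, none or still open, it means among the compounds named here.

Measured compounds:
- compound 1 `Cc1cccc(C)c1C(=O)Nc1nnc(-c2ccc(Cl)cc2)s1`: 69.2 nM
- compound 2 `O=C(Nc1nnc(-c2ccc(Cl)cc2)s1)c1ccccc1F`: 724 nM
- compound 3 `COc1cccc(OC)c1C(=O)Nc1nnc(-c2ccc(C)cc2)s1`: 1230 nM

In a functional assay on the whole organism (integument) for inhibition, with Chilo suppressalis as the target, read by scintillation counting, with a stated time of 72 h (a higher number here means a weaker inhibitor, a lower number a stronger inhibitor), compound 1 gives 69.2 nM, compound 2 gives 724 nM and compound 3 gives 1230 nM. Compound 3 stands at the highest number of the three. Its gap to compound 2 lies within the scatter, so no order between the two can be read; its gap to compound 1 lies beyond the scatter, and compound 1 inhibits more strongly than compound 3 on these numbers.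

Compound 4 `COc1cccc(OC)c1C(=O)Nc1nnc(-c2ccc(-c3ccccc3)cc2)s1` is the next compound to be measured in this assay. It differs from compound 3 in one place: phenyl in place of methyl on an aromatic carbon

Within the data shown here, no pair among the measured compounds separates this change, so there is no step to rest an expectation on. The step from compound 3 to compound 4 is expected to be small, a 1.2-fold lower number from compound 3 to compound 4 (0.09 log units; within the scatter), with no direction claimed beyond the scatter. Compound 4 is estimated at 1000 nM, within a wide range from 250 nM to 4000 nM.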

Compound 4, half-maximal inhibitory concentration: 195 nM
The estimate for compound 4 lay 5.1-fold (0.71 log units) above the measured number; measured number below the stated range.
By their numbers in this assay, from the lowest: compound 1; then compound 4; then compounds 2 and 3 (each within the scatter of the next).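

In this assay, among these compounds, phenyl in place of methyl on an aromatic carbon, para to a large group, gives a 6.3-fold lower number from compound 3 to compound 4 (0.80 log units; beyond the scatter), the only single-place step available. This position therefore accepts a phenyl ring of 6 heavy atoms in place of a single carbon, and the inhibitory number falls rather than rises with that larger group. No measurement in hand accounts for this fall.

From the compounds shown here alone, whether the gain belongs to the aromatic ring or simply to added carbon stays open, and a longer alkyl chain, a cyclohexyl ring, an amine or a carboxylic acid on this carbon would help to separate these readings. Also open, going by these compounds, is whether phenyl brings a similar step when the two methoxy groups of compound 4 are replaced by the two methyl groups of compound 1.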